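The compounds below may be only part of what the source reports. "The series", "measured", "known", "first", "only" and "open" are said of these compounds alone.

Within the data shown here, compound 1 `O=C(Nc1ccc(Cl)c(-c2nnc3c(Cl)cccn23)c1)c1ccccn1` is the reference point of the two compounds measured so far: in a functional assay on MCF7 cells (Homo sapiens) for antiproliferative activity, read by MTT assay, with a stated time of 72 h (a higher number here means a weaker inhibitor, a lower number a stronger inhibitor), compound 1 gives 96400 nM. Compound 2 `Cc1cc(Cl)ccc1C(=O)Nc1ccc(Cl)c(-c2nnc3c(Cl)cccn23)c1` carries a 4-chloro-2-methylphenyl in place of the pyridin-2-yl on the carbonyl carbon. For compound 2 this assay returns only a limit, > 100000 nM. Among the measured compounds shown here, the one measured step, an at least 1.0-fold higher number from compound 1 to compound 2 (0.01 log units; that floor lies within the scatter), therefore rests on a limit rather than a number, and compound 2 stands on the weak side of the series with only a range known for it (the limit of > 100000 nM in this assay, at which 1 of the 2 values shown sits). Compound 3 `O=C(Nc1ccc(Cl)c(-c2nnc3c(Cl)cccn23)c1)c1ccc(Cl)cc1Cl` is the next analogue: chloro in place of methyl on an aromatic carbon. For the measured compounds named here, no measured step reports this exchange, so the only guide is that both measured compounds sit at the weak end of the range. The step of a number no higher from compound 2 to compound 3 (the limit leaves the size open) is expected to stay within the scatter, with no direction claimed. For compound 3 the value is estimated at 100000 nM, within 40000 nM to 250000 nM, with a fair chance that this assay again reports only a limit.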

Compound 3, half-maximal inhibitory concentration: 78200 nM
Compound 3: middle estimate off by 1.3-fold (0.11 log units), on the high side, within the range that was stated.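

In this assay compound 3, with the 2,4-dichlorophenyl on the carbonyl carbon, gives 78200 nM, a measured number. Compound 2, with the 4-chloro-2-methylphenyl on that carbon, returned only a limit. The exchange of methyl for chloro on this aromatic carbon can be read only as an at least 1.2-fold lower number from compound 2 to compound 3 (0.10 log units; that floor lies within the scatter), and that reading is a floor, as the value for compound 2 is a limit and not a number: the limit of > 100000 nM in this assay, at which 1 of the 3 values shown sits.

Against the pyridin-2-yl on the same carbonyl carbon, the 2,4-dichlorophenyl gives a 1.2-fold lower number from compound 1 to compound 3 (0.09 log units; within the scatter), so this exchange does not separate the two compounds in this assay.

It remains open whether any group at this position can move the value beyond the scatter, as each step shown either lies within it or has only a floor within it. Going by these compounds, whether a carboxylic acid or an aminomethyl group on this aromatic ring, or a longer chain in its place, would shift the number in this assay also stays open.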